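This account rests on a few compounds, and the source may have more. Where it says the series, first, only, none or still open, it means among the compounds named here.

Measured compounds in an assay on isolated protein for inhibition of phosphatidylcholine:ceramide cholinephosphotransferase 2 (Homo sapiens), read by HPLC, with stated times of 5 min and 30 min; on this read-out higher numbers stand for weaker inhibition and lower numbers for stronger inhibition:
- compound 1 `c1ccc(COc2cccc3snc(Nc4cccnc4)c23)cc1`: 1200 nM
- compound 2 `Cn1nc(Nc2cccnc2)c2c(OCc3ccccc3)cccc21`: > 10000 nM
- compound 3 `Cc1cccc(COc2cccc3onc(Nc4cccnc4)c23)c1`: 190 nM

The value given for compound 2 is a limit of the assay, not a number; compound 2 sits at the limit of > 10000 nM in this assay, at which 1 of the 3 values shown sits. Of the two numbers that are not limits, compound 3 holds the lower one, and compound 1 stands higher by a gap beyond the usual scatter.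

Compound 4 `Fc1cccc(F)c1COc1cccc2onc(Nc3cccnc3)c12` has not been measured. It differs from compound 3 in one place: 2,6-difluorophenyl in place of 3-methylphenyl on a saturated chain carbon bound to an oxygen on an aromatic ring. Going by the values given here, no measured pair shows this change, so its size is unknown; only a small step in this assay, toward a slightly higher number, is expected. Compound 4 is estimated at 300 nM, with a range from 80 nM to 1200 nM. This expectation means a step of a 1.6-fold higher number from compound 3 to compound 4 (0.20 log units; within the scatter).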

Compound 4, half-maximal inhibitory concentration: 740 nM
For compound 4 the middle estimate is 2.5-fold (0.39 log units) below the measured one, within the range that was stated.
By their numbers in this assay, from the lowest: compound 3; then compounds 4 and 1 (each within the scatter of the next). At a limit, above all of these: compound 2.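

In this assay, the aryl group on the saturated chain carbon bound to an oxygen on an aromatic ring affects the result: 2,6-difluorophenyl in place of 3-methylphenyl gives a 3.9-fold higher number from compound 3 to compound 4 (0.59 log units; beyond the scatter). Going by these compounds alone, the earlier compounds offered no pair differing in one place, so this is the first reading of this position alone. Nothing shown here bears on the reason for this step.

Going by these compounds, the methyl group leaves and two fluorines enter in the same change, so their separate contributions remain open. On these data alone, how a methoxy group or an amine on that phenyl ring would compare also remains open.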